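A few compounds are considered here, and "the series" means these few. Any claim that something is new, unique, unknown or untested is made for them only; others in the source may bear on it.

Measured compounds:
compound 1, `Cc1ccc2nc(N/N=C/c3cccnc3Nc3ccccc3)sc2c1`: 1690 nM
compound 2, `CC(=O)N1N=C(C)/C(=N\Nc2cccc(-c3nc4ccccc4s3)c2)C1=O`: 12300 nM

Of the compounds shown here, two have been measured in a functional assay on MCF7 cells (Homo sapiens) for inhibition; a higher number here means a weaker inhibitor, a lower number a stronger inhibitor. Compound 1 gives 1690 nM, the lowest of the two numbers. Compound 2 gives 12300 nM in this assay, and the gap between the two numbers lies beyond the usual scatter, so compound 1 is the stronger inhibitor of the pair. The two compounds differ in more than one place, so no single structural step can be read from their values.

Compound 3, `Cc1ccc2nc(N/N=C/c3cccnc3Nc3ccc(Cl)cc3)sc2c1`, has not yet been measured. It differs from compound 1 in one place: chloro in place of hydrogen on an aromatic carbon. Going by the values given here, no measured pair shows the effect of this kind of change, so there is no step on which to lean. Among the compounds with values here, with the only comparable number being that of compound 1 at 1690 nM, the expectation is a small step in this assay, likely no larger than the scatter, and if anything toward a lower number. The step from compound 1 to compound 3 is therefore estimated at a 1.4-fold lower number from compound 1 to compound 3 (0.15 log units; within the scatter). For compound 3 in this assay the estimate is 1200 nM, within a range from 400 nM to 4000 nM.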

Compound 3, half-maximal inhibitory concentration: 1030 nM
For compound 3 the middle estimate is 1.2-fold (0.07 log units) above the measured one; low and high end bracket the measured number.
By their numbers in this assay, from the lowest: compounds 3 and 1 (each within the scatter of the next); then compound 2.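

Going by these compounds alone, compound 3 provides the first step that can be read at a single place in this assay: replacing hydrogen with chloro on an aromatic carbon, para to a large group, turning phenyl into 4-chlorophenyl, gives a 1.6-fold lower number from compound 1 to compound 3 (0.22 log units; within the scatter). This step stays within the scatter, so the measurements do not separate compound 3 from compound 1, and this position carries the chloro without a measurable change in the number. No measured information is available to explain this result.

The compounds shown leave open whether a different group at this same place, such as methoxy, an amine or a carboxylic acid, would move the number beyond the scatter. They also leave open whether chloro on another carbon of this ring, or on a different part of the core of compound 1, would give a step of similar size.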